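The source may report more compounds than this note shows. Statements on the series, on what has been measured and on what is new or still open speak of the compounds shown alone.

Working notes on the series.

Of the compounds shown here, three have been measured in an assay for inhibition of 15-hydroxyprostaglandin dehydrogenase [NAD(+)] (Homo sapiens), read by fluorescence and spectrophotometry; a higher number here means a weaker inhibitor, a lower number a stronger inhibitor. Compound 1, `O=C1N=C(O)S/C1=C\c1ccc(OCCC2CCCCC2)cc1Cl`, gives 13 nM in this assay. Compound 2, `CC(C)OCCOc1ccc(/C=C2\SC(=O)NC2=O)c(Cl)c1`, gives 1050 nM. Compound 3, `CC(C)OCCOc1ccc(/C=C2\SC(O)=NC2=O)cc1Cl`, gives 2740 nM. Among these three numbers compound 1 stands lowest, and its gaps to compound 2 and to compound 3 both lie well beyond the usual scatter of this assay. For the measured compounds named here, compounds 2 and 3 differ from compound 1 in the side chain on the aromatic oxygen and in the shared core, so no single-point step between measured compounds is available to guide the next change.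

Compound 4, `O=C1N=C(O)S/C1=C\c1ccc(OCCCCc2ccccc2)cc1Cl`, keeps the core of compound 1 and alters only the side chain: phenethyl in place of cyclohexyl on a saturated chain carbon, two bonds along the chain from an oxygen on an aromatic ring. Going by the values given here, no measured pair isolates this kind of exchange, so the size of the step cannot be read from the data; the expectation is that compound 4 stays close to compound 1 in this assay, with any movement falling within or only slightly beyond the scatter, direction uncertain. On that basis the estimated step is a 1.5-fold higher number from compound 1 to compound 4 (0.19 log units; within the scatter). Compound 4 is therefore estimated at 20 nM in this assay, with a range from 5 nM to 80 nM.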

Compound 4, half-maximal inhibitory concentration: 81 nM
Estimate against measurement, compound 4: 4.1-fold (0.61 log units) below, and the stated range ends below it.
By their numbers in this assay, from the lowest: compound 1; then compound 4; then compound 2; then compound 3.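

In this assay, for the compounds shown here, the first single-point step shows that this place on the side chain responds to the group it carries: phenethyl in place of cyclohexyl, on a saturated chain carbon, two bonds along the chain from an oxygen on an aromatic ring, gives a 6.2-fold higher number from compound 1 to compound 4 (0.79 log units; beyond the scatter), a modest step beyond the scatter. At this place and on the core of compound 1, the exchange is therefore not neutral, and of these two groups cyclohexyl gives the lower number. No measurement in hand bears on the reason for this step.

The exchange alters two things at once, a six-membered non-aromatic ring becoming a six-membered aromatic ring and 6 heavy atoms becoming 8, so the compounds shown cannot say which of the two carries the step; a 2-cyclohexylethyl group or a phenyl group at the same place would separate them. Also open, from the compounds shown here alone, is how this place would respond to a group of another kind, such as an amine or a carboxylic acid at the end of the chain.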